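A Further Chloro on Compound 2

The source may report more compounds than this note shows. Statements on the series, on what has been measured and on what is new or still open speak of the compounds shown alone.

In a functional assay on COLO 205 cells (Homo sapiens) for cytotoxicity (a lower number here means a stronger inhibitor, a higher number a weaker inhibitor), compound 1 `Cc1ccc(S(=O)(=O)N/C(=N\O)Nc2ccc(Cl)c(Cl)c2)cc1` gives 10 ug/mL, while compound 2 `Cc1ccc(S(=O)(=O)/N=C(\S)Nc2ccc(Cl)cc2)cc1` gives 87 ug/mL, the higher of the two numbers by a gap beyond the scatter. Compound 3 `Cc1ccc(S(=O)(=O)/N=C(\S)Nc2ccc(Cl)c(Cl)c2)cc1` is reached from compound 2 by a single change: chloro in place of hydrogen on an aromatic carbon. The incoming chloro stands ortho to a chloro group and meta to a large group. For the measured compounds named here, no measured pair isolates this change, so only a modest fall in the number is expected, and the estimated move is a 2.2-fold lower number from compound 2 to compound 3 (0.34 log units; beyond the scatter). Compound 3 is expected at 40 ug/mL, with an estimated range of 13 ug/mL to 110 ug/mL.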

Compound 3, half-maximal inhibitory concentration: 45 ug/mL
The estimate for compound 3 lay 1.1-fold (0.05 log units) below the measured number; the measured number falls inside the stated range.
By their numbers in this assay, from the lowest: compound 1; then compounds 3 and 2 (each within the scatter of the next).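

In this assay, chloro in place of hydrogen on an aromatic carbon, ortho to a chloro group and meta to a large group, gives a 1.9-fold lower number from compound 2 to compound 3 (0.29 log units; within the scatter). For the compounds shown here, this is the first step to isolate the change, and it shows that a chloro at this place on compound 2 does not move the number beyond the scatter. Nothing measured here offers an explanation for this result. The compounds shown leave open whether a fluoro, a methoxy group or an amine at this same place would give a step beyond the scatter.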